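Methoxy for fluoro on the benzyl amide: working notes

The compounds below may be only part of what the source reports. "The series", "measured", "known", "first", "only" and "open" are said of these compounds alone.

Measured in a functional assay on L6 cells (Rattus norvegicus) for inhibition, read by scintillation counting, with a stated time of 3 h; on this read-out higher numbers stand for weaker inhibition and lower numbers for stronger inhibition:
compound 1 `COc1ccc(CNC(=O)c2nc(-c3ccc(F)cc3)n(CC[C@@H](O)C[C@@H](O)CC(=O)O)c2C2CC2)cc1F` gives 890 nM
compound 2 `O=C(O)C[C@H](O)C[C@H](O)CCn1c(-c2ccc(F)cc2)nc(C(=O)NCc2ccc(F)c(F)c2)c1C1CC1` gives 2780 nM
compound 3 `O=C(O)C[C@H](O)C[C@H](O)CCn1c(-c2ccc(F)cc2)nc(C(=O)NCc2ccc(F)cc2)c1C1CC1` gives 1620 nM

Compound 4 `COc1ccc(CNC(=O)c2nc(-c3ccc(F)cc3)n(CC[C@@H](O)C[C@@H](O)CC(=O)O)c2C2CC2)cc1` is not yet measured. It differs from compound 3 by methoxy in place of fluoro on an aromatic carbon. The same kind of change occurs once among the measured compounds: compound 1 differs from compound 2 by methoxy in place of fluoro on an aromatic carbon, and that step read a 3.1-fold lower number from compound 2 to compound 1 (0.49 log units; beyond the scatter). The two cores differ by hydrogen in place of fluoro on an aromatic carbon. The surroundings of the place are not identical: in compound 2 the exchanged fluoro stands ortho to a fluoro group and para to a large group, while in compound 3 it stands para to a large group only, so the change is the same kind of change, not the same. Removing that fluoro gave a 1.7-fold lower number from compound 2 to compound 3 (0.23 log units; within the scatter), and compound 1 against compound 3 reads a 1.8-fold higher number from compound 1 to compound 3 (0.26 log units; within the scatter). In this assay, for the measured compounds named here, the expected step is a 2.5-fold lower number from compound 3 to compound 4 (0.40 log units; beyond the scatter), resting on the single earlier step of a 3.1-fold lower number from compound 2 to compound 1 (0.49 log units; beyond the scatter), taken at a somewhat reduced size since one example is thin support. Compound 4 is therefore estimated at 650 nM, with a likely range from 300 nM to 1400 nM.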

Compound 4, half-maximal inhibitory concentration in the L6 assay: 6400 nM
For compound 4 the middle estimate is 9.8-fold (0.99 log units) below the measured one; measured number outside the range, above it.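

Methoxy for fluoro does not carry from one core to the other in the L6 assay, where the step changes direction from a 3.1-fold lower number from compound 2 to compound 1 (0.49 log units; beyond the scatter) to a 4.0-fold higher number from compound 3 to compound 4 (0.60 log units; beyond the scatter): the same change on two cores in the L6 assay, a 3.1-fold lower number (0.49 log units; beyond the scatter) from compound 2 to compound 1 and a 4.0-fold higher number (0.60 log units; beyond the scatter) from compound 3 to compound 4, 12-fold (1.09 log units) apart, beyond the scatter of two such steps
Read the other way, hydrogen for fluoro is small on the fluoro side of the set but large on the methoxy side, with a 7.2-fold higher number from compound 1 to compound 4 (0.86 log units; beyond the scatter) as the large case: the same change on two cores in the L6 assay, a 1.7-fold lower number (0.23 log units; within the scatter) from compound 2 to compound 3 and a 7.2-fold higher number (0.86 log units; beyond the scatter) from compound 1 to compound 4, 12-fold (1.09 log units) apart, beyond the scatter of two such steps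
The two changes therefore do not add in these four compounds, and in the L6 assay the steps of a 4.0-fold higher number from compound 3 to compound 4 (0.60 log units; beyond the scatter) together with a 2.3-fold higher number from compound 2 to compound 4 (0.36 log units; beyond the scatter) place compound 4 apart from the fluoro compounds, but a single pair per core gives neither a cause nor a rule for any further core. In a physicochemical assay for lipophilicity, using the shake flask method, at pH 7.4 (a lower number here means a more polar compound, a higher number a more lipophilic compound), compound 3 gives 0.17 and compound 4 gives 0.02, and that pair reads only a number 0.15 log units lower from compound 3 to compound 4 (within the scatter).

Open, going by these compounds, is whether the turn in direction belongs to methoxy alone or also appears with other groups in the same place, such as chloro, methyl or ethoxy. Also open, on these data alone, is whether a chloro in place of the extra fluoro of compound 1 would preserve the lower number seen there.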